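The compounds below may be only part of what the source reports. "The series", "measured", "known", "first", "only" and "open" are said of these compounds alone.

Measured so far:
- compound 1 `COc1cc(-c2ccnc3cc(-c4ccc(F)cc4)nn23)cc(OC)c1OC`: 3800 nM
- compound 2 `COc1cc(-c2ccnc3cc(-c4ccc5c(ccn5C)c4)nn23)cc(OC)c1OC`: 15 nM

In a functional assay on A549 cells (Homo sapiens) for inhibition, read by CCK-8 assay, with a stated time of 48 h (a lower number here means a stronger inhibitor, a higher number a weaker inhibitor), compound 1 gives the highest of these two numbers. Going by the values given here, the only measured step, a 250-fold lower number from compound 1 to compound 2 (2.40 log units; beyond the scatter), exchanged the whole aromatic group rather than a single substituent on it.

Compound 3 `CCOC(=O)c1ccc(-c2cc3nccc(-c4cc(OC)c(OC)c(OC)c4)n3n2)cc1` differs from compound 1 as follows: ethoxycarbonyl in place of fluoro on an aromatic carbon. Among the compounds with values here, no measured step concerns a substituent at this place, so the large step seen earlier offers no direct guide, and its size is not carried over.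

The expected outcome is no step beyond the scatter: the estimate for compound 3 is 3000 nM, between 700 nM and 12000 nM, meaning an expected 1.3-fold lower number from compound 1 to compound 3 (0.10 log units; within the scatter).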

Compound 3, half-maximal inhibitory concentration: > 10000 nM
Compound 3 gave a limit, no number; the forecaster's own chance of this, stated with the estimate: 10%; at least 3.3-fold (0.52 log units) between middle value and limit.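

In this assay, ethoxycarbonyl in place of fluoro on this aromatic carbon, para to a large group, gives an at least 2.6-fold higher number from compound 1 to compound 3 (0.42 log units; beyond the scatter), so a substituent change at this place alone can move the number beyond the scatter. Compound 3 gives a limit, not a number: the limit of > 10000 nM in this assay, at which 1 of the 3 values shown sits. The direction of the step is therefore known, but not its full size.

The compounds shown leave open whether a carboxylic acid or an amine at this place would behave like the ethoxycarbonyl group. They also do not separate the effect of the ester from that of the added heavy atoms.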